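The source may hold more compounds than are shown below. What is called first, only, known or untested is meant among the compounds shown, and "the series" means these compounds.

Compounds measured in an assay on HEK-293T cells for displacement of a labelled ligand from corticotropin-releasing factor receptor 2 (Homo sapiens), read by scintillation counting, with a stated time of 2 h, tested at 1 uM; a higher number here means more inhibition at the concentration tested (going by the name of the read-out), a lower number less inhibition:

Compound 1, `CCCCN(CC)c1cc(C)nc2c1NC(=O)CN2c1ccc(C(C)(C)C)cc1Br`: -3.8%
Compound 2, `CCCCN(CC)c1cc(C)nc2c1NC(=O)CN2c1ccc(Br)cc1Cl`: "not determined" (no result reported)
Compound 3, `CCCCN(CC)c1cc(C)nc2c1NC(=O)CN2c1ccc(C)cc1Br`: 5.5%

All three share one core and differ only in the aryl group attached to the ring nitrogen. Compound 1 and compound 3 both show essentially no displacement of the labelled ligand. Compound 2 stands without a number: its result in this assay was not reported, so it is a measured neighbour without a value.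

Compound 4, `CCCCN(CC)c1cc(C)nc2c1NC(=O)CN2c1ccc(OC)cc1C`, differs from compound 2 in one place: 4-methoxy-2-methylphenyl in place of 4-bromo-2-chlorophenyl on a nitrogen on an aromatic ring in a ring.

For the measured compounds named here, only one measured step exists, a number 9.3 percentage points higher from compound 1 to compound 3 (within the scatter), which swaps a single group on that same aryl ring and leaves the read-out near zero at both ends. Going by the values given here, no measured step covers the change from compound 2 to compound 4, which replaces both substituents at once, so it bears only loosely. With every known value near zero, no step beyond the scatter is expected for compound 4. Compound 4 is expected to give about 3%, with a likely range from -12% to 18%.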

Compound 4, a percentage reported as inhibition, at one concentration (the size of the read-out at that concentration, not a potency): -2.3%
Beside the measured number, compound 4's estimate is 5.3 percentage points above it; the range from low to high includes it.
By their numbers in this assay, from the lowest: compounds 1, 4 and 3 (each within the scatter of the next).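

Replacing 2-bromo-4-methylphenyl with 4-methoxy-2-methylphenyl in this assay gives a number 7.8 percentage points lower from compound 3 to compound 4 (within the scatter), so a methoxy group on this aryl ring does not move the read-out beyond the scatter. Compound 4 has no halogen on that ring, yet it stays within the scatter of the bromine-bearing compound 3, and both sit close to zero. Nothing measured here explains why this swap makes so little difference.

The step from compound 2 to compound 4 cannot be read, as compound 2 has no number. As far as these compounds go, whether any group at this position can produce clear displacement stays open, for example an aryl ring carrying an amine or a carboxylic acid.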